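A few compounds are considered here, and "the series" means these few. Any claim that something is new, unique, unknown or untested is made for them only; others in the source may bear on it.

Working notes on the series.

Compound 2 `CC[C@](C)(O)CC(=O)O[C@H](CC=C(C)C)C1=CC(=O)c2c(O)ccc(O)c2C1=O` gives the lowest number of the three measured in a functional assay on HeLa cells (Homo sapiens) for cytotoxicity, read by MTT assay; a higher number here means a weaker inhibitor, a lower number a stronger inhibitor: compound 2 gives 30200 nM. Compound 1 `CCCCC(O)CC(=O)O[C@H](CC=C(C)C)C1=CC(=O)c2c(O)ccc(O)c2C1=O` gives 72200 nM in this assay, and compound 3 `CCCCC(CC(=O)O[C@H](CC=C(C)C)C1=CC(=O)c2c(O)ccc(O)c2C1=O)OC(C)=O` gives 73500 nM. The step of a 2.4-fold lower number from compound 1 to compound 2 (0.38 log units; beyond the scatter) and the step of a 2.4-fold higher number from compound 2 to compound 3 (0.39 log units; beyond the scatter) are both modest, while a 1.0-fold higher number from compound 1 to compound 3 (0.01 log units; within the scatter) lies within the scatter; so changes confined to the acyl part of the ester move the number only a little.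

Compound 4 `CC(C)=CC[C@@H](OCCO)C1=CC(=O)c2c(O)ccc(O)c2C1=O` is not yet measured. It differs from compound 2 at one place: 2-hydroxyethyl in place of (2-hydroxy-2-methylbutyl)carbonyl on an oxygen on a saturated carbon. Going by the values given here, none of the measured steps tests this kind of change, since all three keep an ester at that oxygen and differ only in the acyl group; the measured steps therefore bear on it only loosely, and they show that this region tolerates alteration without large movement. The expectation is a number for compound 4 near the range spanned by compounds 1 to 3, placed slightly above compound 2, with the step of a 2.0-fold higher number from compound 2 to compound 4 (0.30 log units; within the scatter) estimated as a small loss rather than a gain. Compound 4 is thus estimated at 60000 nM, with a range from 15000 nM to 250000 nM.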

Compound 4, half-maximal inhibitory concentration: 18600 nM
The estimate for compound 4 lay 3.2-fold (0.51 log units) above the measured number, within the range that was stated.
By their numbers in this assay, from the lowest: compounds 4 and 2 (each within the scatter of the next); then compounds 1 and 3 (each within the scatter of the next).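

The earlier steps shown here all kept an ester at this oxygen and changed only the acyl group, whereas here the whole (2-hydroxy-2-methylbutyl)carbonyl group gives way to the smaller 2-hydroxyethyl. In this assay, a 1.6-fold lower number from compound 2 to compound 4 (0.21 log units; within the scatter), so within this pair the ester carbonyl can be lost with no change that can be told from the scatter, and the acyl group's 8 heavy atoms can be cut to 3. Against the (2-hydroxyhexyl)carbonyl group the same kind of replacement gives a 3.9-fold lower number from compound 1 to compound 4 (0.59 log units; beyond the scatter), a modest step beyond the scatter, and no measurement at hand explains the difference between these two pairs.

On these data alone, it remains open whether the hydroxyl of 2-hydroxyethyl contributes at all, which a plain ethyl group or an amine at the end of that chain would test. As far as these compounds go, it is also open how the number responds to chain length at this oxygen, for instance with 4-hydroxybutyl, or to a carboxylic acid at the chain end.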